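The source may report more compounds than this note shows. Statements on the series, on what has been measured and on what is new or still open speak of the compounds shown alone.

Measured compounds:
compound 1, `O=C(c1ccco1)N(C(=O)c1ccco1)c1nc(-c2ccccc2)nc2cn(-c3ccccc3)nc12`: 3%
compound 2, `CC(=O)Nc1nc(C)nc2cn(-c3ccccc3)nc12`: 25%
compound 3, `COc1ccc(-n2cc3nc(C)nc(NC(=O)Nc4ccccc4)c3n2)cc1`: 5%

Of the compounds shown here, three sharing one core have been tested in an assay on CHO cells for displacement of a labelled ligand from adenosine receptor A1 (Homo sapiens), read by scintillation counting, with a stated time of 120 min, tested at 1 uM; a higher number here means more inhibition at the concentration tested (going by the name of the read-out), a lower number less inhibition. Compound 1, `O=C(c1ccco1)N(C(=O)c1ccco1)c1nc(-c2ccccc2)nc2cn(-c3ccccc3)nc12`, gives 3%. Compound 2, `CC(=O)Nc1nc(C)nc2cn(-c3ccccc3)nc12`, gives 25%. Compound 3, `COc1ccc(-n2cc3nc(C)nc(NC(=O)Nc4ccccc4)c3n2)cc1`, gives 5%. Compound 2 therefore stands highest of the three numbers, and its gaps to compound 3 and to compound 1 both lie beyond the usual scatter of this assay.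

Compound 4, `COc1ccc(C(=O)Nc2nc(C)nc3cn(-c4ccccc4)nc23)cc1`, is the next compound to be measured. It differs from compound 2 in a single place: 4-methoxyphenyl in place of methyl on a carbonyl carbon. Among the measured compounds shown here, the only guide is that compound 1 and compound 3, which both carry larger groups on that carbonyl carbon, give lower numbers than compound 2 in this assay. On that basis a drop is expected, and the expected step from compound 2 to compound 4 is a number 15 percentage points lower from compound 2 to compound 4 (beyond the scatter), likely beyond the scatter though not certainly so. Compound 4 is estimated to give 10% in this assay, with a range from -5% to 28%.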

Compound 4, a percentage reported as inhibition, at one concentration (the size of the read-out at that concentration, not a potency): 4%
The estimate for compound 4 lay 6 percentage points above the measured number; measured number inside the range.
By their numbers in this assay, from the lowest: compounds 1, 4 and 3 (each within the scatter of the next); then compound 2.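

In this assay, putting 4-methoxyphenyl in place of methyl on the carbonyl carbon gives a number 21 percentage points lower from compound 2 to compound 4 (beyond the scatter), and this is the only pair shown that isolates a change at this position. Since nothing else differs between the two structures, the position is not indifferent to its group: here, the bigger group, which brings an aromatic ring and an extra hydrogen-bond acceptor, goes with less inhibition at the concentration tested. However, no measurement shown explains why the number falls, and this one pair cannot separate the contribution of the ring from that of the methoxy group.

A plain phenyl or an ethyl group on that carbonyl carbon could show how much of the change each part accounts for. Going by these compounds, whether an amine or a carboxylic acid there could raise the number above that of compound 2 remains open.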